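One Added Methyl Group and Its Expected Cost

The compounds below may be only part of what the source reports. "The series", "measured", "known", "first", "only" and "open" are said of these compounds alone.

Measured so far in the whole-animal test:
compound 1, `COc1cc(C)nc(C(=O)Nc2nn[nH]n2)c1`: 20%
compound 2, `Cc1ccc(C(=O)Nc2nn[nH]n2)nc1`: 42%
compound 3, `COc1ccnc(C(=O)Nc2nn[nH]n2)c1`: 88%

In a functional assay on the whole organism for inhibition, with Rattus norvegicus as the target, at a dose of 10 mg/kg by the oral route (on this read-out lower numbers stand for a weaker effect and higher numbers for a stronger effect at the one dose given), compound 3 gives 88%, the highest of the three. Compound 1 gives 20% and compound 2 gives 42%. Compound 3 turns into compound 1 by one change, (methyl in place of hydrogen on an aromatic carbon), and that step is a number 68 percentage points lower from compound 3 to compound 1 (beyond the scatter). Compound 4, `Cc1ccc(C(=O)Nc2nn[nH]n2)nc1C`, is not yet measured; it arises from compound 2 by methyl in place of hydrogen on an aromatic carbon. The difference between the cores of compound 2 and compound 3 is not broken down here. The two changes are of the same kind, not the same: in compound 1 the new methyl sits meta to a methoxy group, in compound 4 ortho to a methyl group. The expected step is a number 27 percentage points lower from compound 2 to compound 4 (beyond the scatter), which rests on the measured step of a number 68 percentage points lower from compound 3 to compound 1 (beyond the scatter). In this assay compound 4 is expected to give 15%, between 0% and 40%.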

Compound 4, a percentage reported as inhibition, in the whole organism at one dose (the size of the read-out at that dose, not a potency): 42%
Estimate against measurement, compound 4: 27 percentage points below; measured number outside the range, above it.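

Placing a methyl on an aromatic carbon of the core of compound 2 gives, in this assay, no change at the digits printed from compound 2 to compound 4 (within the scatter). The size of this change's effect therefore does not carry over from one core to the other in this series: the same change on two cores in this assay, a number 68 percentage points lower (beyond the scatter) from compound 3 to compound 1 and no change at the digits printed (within the scatter) from compound 2 to compound 4, 68 percentage points apart, beyond the scatter of two such steps. These two pairs do not show whether the core or the exact place of the methyl decides the outcome, and they give no rule for a third core.

The compounds shown leave open what an amine or a longer chain would do on the same aromatic carbon in place of the methyl of compound 4. They also leave open how the read-out would respond to either group on the core of compound 3.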